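A Chloro Substituent on Three Related Alkynyl Quinoxalines

The source may hold more compounds than are shown below. What is called first, only, known or untested is meant among the compounds shown, and "the series" means these compounds.

Of the compounds shown here, three have been measured so far in an ADME assay on RAW264.7 cells (Mus musculus) for cytotoxicity, read by MTT assay, with a stated time of 24 h; on this read-out lower numbers stand for stronger inhibition and higher numbers for weaker inhibition. Compound 1 `OCC#Cc1cnc2ccccc2n1` gives 43700 nM. Compound 2 `OCC#Cc1cnc2cc(Cl)ccc2n1` carries one change compared with compound 1, namely (chloro in place of hydrogen on an aromatic carbon), and in this assay compound 2 gives 35300 nM. That change produced a 1.2-fold lower number from compound 1 to compound 2 (0.09 log units; within the scatter). Compound 3 `CC(=O)OCC#Cc1cnc2ccccc2n1` differs from compound 1 in a different place, namely (acetyl in place of hydrogen on an oxygen on a saturated carbon), and in this assay compound 3 gives 47700 nM. That change produced a 1.1-fold higher number from compound 1 to compound 3 (0.04 log units; within the scatter). All three numbers sit within the usual scatter of one another, so no order among them can be read from these data.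

Compound 4 `CC(=O)OCC#Cc1cnc2cc(Cl)ccc2n1` has not yet been measured. It differs from compound 3 by chloro in place of hydrogen on an aromatic carbon. This is the same change that was made from compound 1 to compound 2, made here on the core of compound 3, which itself differs from the core of compound 1 by the acetyl group described above. Among the measured compounds shown here, the only guide available is that earlier step, which stayed within the scatter. On that basis the step from compound 3 to compound 4 is expected to be about a 1.2-fold lower number from compound 3 to compound 4 (0.08 log units; within the scatter), resting on the earlier step of a 1.2-fold lower number from compound 1 to compound 2 (0.09 log units; within the scatter). Compound 4 is therefore expected to give roughly 40000 nM, with an estimated range from 20000 nM to 80000 nM.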

Compound 4, half-maximal inhibitory concentration: 20200 nM
Compound 4: middle estimate off by 2.0-fold (0.30 log units), on the high side; measured number inside the range.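

Chloro in place of hydrogen on the core of compound 3 gives a 2.4-fold lower number from compound 3 to compound 4 (0.37 log units; beyond the scatter) in this assay, whereas the same change on the core of compound 1 stayed within the scatter, but the two steps cannot be told apart: the same change on two cores in this assay, a 1.2-fold lower number (0.09 log units; within the scatter) from compound 1 to compound 2 and a 2.4-fold lower number (0.37 log units; beyond the scatter) from compound 3 to compound 4, 1.9-fold (0.28 log units) apart, within the scatter of two such steps The acetyl change, made on the chlorinated core, gives a 1.7-fold lower number from compound 2 to compound 4 (0.24 log units; within the scatter), and it too cannot be told apart from its counterpart on the core of compound 1: the same change on two cores in this assay, a 1.1-fold higher number (0.04 log units; within the scatter) from compound 1 to compound 3 and a 1.7-fold lower number (0.24 log units; within the scatter) from compound 2 to compound 4, 1.9-fold (0.28 log units) apart, within the scatter of two such steps So these four compounds fit each change carrying over between the two cores at a similar size, but with only one pair of steps per change, they neither prove that the steps are equal nor show that chloro does more when the acetyl group is present.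

The compounds shown leave open whether the same carry-over would hold for a fluoro or methoxy group in place of the chloro, or for chloro on another carbon of the ring. They also leave open what a longer ester such as butyryl, or an amine in place of the oxygen-bearing end of the chain, would do to the number in this assay.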